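A few compounds are considered here, and "the series" means these few. Any claim that something is new, unique, unknown or untested is made for them only; others in the source may bear on it.

Measured so far in a functional assay on IMR-32 cells (Homo sapiens) for inhibition, read by sulforhodamine B assay, with a stated time of 48 h; on this read-out lower numbers stand for stronger inhibition of growth and higher numbers for weaker inhibition of growth:

Compound 1 `Cc1ccc(/C=N\NC(=O)C2=C(Cl)c3ccccc3CCC2)cc1` gives 140 nM in this assay.
Compound 2 `COc1cccc(/C=N\NC(=O)C2=C(Cl)c3ccccc3CCC2)c1` sits at a limit of this assay, reported as < 10 nM.
Compound 3 `O=C(N/N=C\c1ccc(Cl)cc1)C1=C(Cl)c2ccccc2CCC1` gives 140 nM in this assay.

Among the compounds with values here, compound 3 stands level with compound 1, the step of no change at the digits printed from compound 1 to compound 3 (within the scatter) being within the usual scatter of this assay; the only other value shown, that of compound 2, is a limit rather than a number.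

Compound 4 `O=C(N/N=C\c1ccc(F)cc1)C1=C(Cl)c2ccccc2CCC1` has not yet been measured. It differs from compound 3 in one place: fluoro in place of chloro on an aromatic carbon.

Within the data shown here, the step that bears most directly on this change is the one from compound 1 to compound 3, where chloro replaced methyl on the same aromatic carbon and the read-out did not move: no change at the digits printed from compound 1 to compound 3 (within the scatter). The two large steps, an at least 14-fold lower number from compound 1 to compound 2 (1.14 log units; beyond the scatter) and an at least 14-fold higher number from compound 2 to compound 3 (1.14 log units; beyond the scatter), each involve a different substituent at a different place on the ring, so they say little about a swap of one substituent for another at the same place. On that basis, the change from compound 3 to compound 4 is expected to give no step beyond the scatter, no change at the digits printed from compound 3 to compound 4 (within the scatter).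

Compound 4 is therefore estimated at 140 nM, with a range from 50 nM to 400 nM.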

Compound 4, concentration for 50% growth inhibition: 270 nM
Compound 4: middle estimate off by 1.9-fold (0.29 log units), on the low side; the range from low to high includes it.
By their numbers in this assay, from the lowest: compounds 1, 3 and 4 (each within the scatter of the next). At a limit, below all of these: compound 2.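

In this assay, the aromatic carbon para to a large group now carries a third substituent, and neither new step leaves the scatter, with a 1.9-fold higher number from compound 3 to compound 4 (0.29 log units; within the scatter) and a 1.9-fold higher number from compound 1 to compound 4 (0.29 log units; within the scatter), so methyl, chloro and fluoro at this place read alike across compounds 1, 3 and 4. Fluoro does not close the gap to the 3-methoxyphenyl group either, as the swap to 4-fluorophenyl gives an at least 27-fold higher number from compound 2 to compound 4 (1.43 log units; beyond the scatter). Compound 2 is a limit rather than a number, so that step gives only a floor for the gap: the limit of < 10 nM in this assay, at which 1 of the 4 values shown sits.

Within the data shown here, what stays open is whether this gap follows the methoxy group itself or the place it occupies, as no compound here holds methoxy on the carbon para to a large group. Also open is how this place responds to groups of a different kind, such as an amine or a carboxylic acid, as methyl, chloro and fluoro are the only groups shown there.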